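Oral exposure in the series: acylsulfonamide to acetamide

The source may report more compounds than this note shows. Statements on the series, on what has been measured and on what is new or still open speak of the compounds shown alone.

Among the compounds with values here, compound 2 `CCCCN(c1nc2c(C(=O)NS(C)(=O)=O)cccc2o1)[C@H](C)c1ccc(-c2ccccc2-c2nnn[nH]2)cc1` gives 40.4 nM in an ADME assay on the whole organism (Macaca fascicularis) for pharmacokinetics, read by LC-MS, using cassette dosing, at a dose of 1 mg/kg by the oral route (a higher number here means more compound in the circulation at the dose given, a lower number less compound in the circulation), the lower of the two numbers so far, while compound 1 `CCCCN(c1nc2c(-c3nccn3C)cccc2o1)[C@H](C)c1ccc(-c2ccccc2-c2nnn[nH]2)cc1` gives 154 nM. Within the data shown here, the single measured step, a 3.8-fold lower number from compound 1 to compound 2 (0.58 log units; beyond the scatter), exchanged a group on the same aromatic carbon of the shared core and lowered the number by a modest amount. Compound 3 `CCCCN(c1nc2c(NC(C)=O)cccc2o1)[C@H](C)c1ccc(-c2ccccc2-c2nnn[nH]2)cc1` carries acetamido in place of (methylsulfonyl)carbamoyl on an aromatic carbon. Among the measured compounds shown here, no measured step covers this exact exchange, and the one step at this position is the only guide, so both size and direction are uncertain. For the measured compounds named here, since the group being removed is the one present in the compound with the lower value, a drift back toward the value of compound 1 is plausible, but nothing larger than the single measured step is anticipated. Compound 3 is therefore estimated at 70 nM (range 25 nM to 200 nM), which means an expected step of a 1.7-fold higher number from compound 2 to compound 3 (0.24 log units; within the scatter), within or only just beyond the scatter.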

Compound 3, maximal plasma concentration: 26.6 nM
The estimate for compound 3 lay 2.6-fold (0.42 log units) above the measured number; low and high end bracket the measured number.
By their numbers in this assay, from the lowest: compounds 3 and 2 (each within the scatter of the next); then compound 1.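

In this assay, the exchange at this aromatic carbon gives a 1.5-fold lower number from compound 2 to compound 3 (0.18 log units; within the scatter), so (methylsulfonyl)carbamoyl and acetamido cannot be told apart here, even though they differ in heavy-atom count and in hydrogen-bond acceptors. Set against the 1-methyl-1H-imidazol-2-yl group of compound 1, acetamido gives a 5.8-fold lower number from compound 1 to compound 3 (0.76 log units; beyond the scatter), so both acyclic groups shown now stand apart from the one ring-bearing group, and the higher number rests on compound 1 alone. Nothing at hand explains this difference.

On these data alone, whether the higher number belongs to 1-methyl-1H-imidazol-2-yl in particular or to aromatic rings at this carbon more generally stays open, and a pyridine or an unsubstituted imidazole would bear on that. A primary amine or a carboxylic acid at the same carbon could equally fall with either side of the present split.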